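Carbamoyl to acetyl: working notes on compound 4

This account rests on a few compounds, and the source may have more. Where it says the series, first, only, none or still open, it means among the compounds named here.

Measured so far in an ADME assay on a cell-free system (plasma, Homo sapiens) for metabolic stability, read by HPLC; a lower number here means that the compound disappears faster, a higher number that the compound lasts longer:
- compound 1 `CN(/N=N/c1ccc(C(N)=O)cc1)C(=O)CCc1ccc(O)cc1` gives 48.5 h
- compound 2 `CC(=O)c1ccc(/N=N/N(C)C(=O)CCCCc2ccc(O)cc2)cc1` gives 32.7 h
- compound 3 `COC(=O)c1ccc(/N=N/N(C)C(=O)CCCCc2ccc(O)cc2)cc1` gives 17.5 h

Compound 1 at 48.5 h lies within the scatter of compound 2 and beyond the scatter above compound 3. The next step leads to compound 4 `CC(=O)c1ccc(/N=N/N(C)C(=O)CCc2ccc(O)cc2)cc1` and reads methyl in place of amino on a carbonyl carbon as a change of carbamoyl to acetyl, with methyl in place of amino on a carbonyl carbon. The chain of compound 1 stays in place.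

Among the measured compounds shown here, no measured step shows this exact replacement. The closest is a 1.9-fold lower number from compound 2 to compound 3 (0.27 log units; within the scatter) and it lies within the scatter, with methoxy in place of methyl on a carbonyl carbon. It shows a replacement at this kind of carbon, but amino plays no part in it. Compound 2 at 32.7 h already carries the acetyl group of compound 4, though on a different chain, so its value serves as a guide and not as a direct match.

On this basis, a small drop that stays within the scatter is expected in this assay. The expected step is a 1.3-fold lower number from compound 1 to compound 4 (0.11 log units; within the scatter) and this remains an estimate. Compound 4 is expected at 38 h with an estimated range from 20 h to 70 h in this measurement.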

Compound 4, half-life: 14.6 h
Beside the measured number, compound 4's estimate is 2.6-fold (0.42 log units) above it; the whole stated range lies above it.
By their numbers in this assay, from the lowest: compounds 4, 3, 2 and 1 (each within the scatter of the next, the first and the last beyond it).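

In this assay the carbonyl carbon whose other neighbour is an aromatic carbon responds to this replacement with a 3.3-fold lower number from compound 1 to compound 4 (0.52 log units; beyond the scatter) and not only with a change inside the scatter, as seen in the earlier step at this kind of carbon, a 1.9-fold lower number from compound 2 to compound 3 (0.27 log units; within the scatter). With the chain of compound 1 held in place, methyl in place of amino is the first single change shown in the series that reaches beyond the scatter, so carbamoyl and acetyl are not interchangeable on this chain in this measurement. No measurement at hand accounts for the size of this step.

Compound 2 gives 32.7 h and compound 4 gives 14.6 h with the same acetyl group on different chains, and no carbamoyl partner of compound 2 is shown, so it remains open whether the step from carbamoyl to acetyl holds on another chain. Going by these compounds, how a carboxylic acid or a methylamino group in place of amino on this carbonyl carbon would read in this assay also remains open.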